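Changing the Side Chain of Compound 3

This account rests on a few compounds, and the source may have more. Where it says the series, first, only, none or still open, it means among the compounds named here.

Three compounds measured in a functional assay on the whole organism for antagonist activity, with Rattus norvegicus as the target (on this read-out lower numbers stand for an effect already at smaller amounts and higher numbers for an effect only at larger amounts of compound), share one core:
- compound 1 `CN1CCN(C(=O)CCCOc2cc(C(=O)N3CCCCc4sccc43)ccc2NC(=O)c2ccccc2-c2ccccc2)CC1` gives 0.03 mg/kg
- compound 2 `O=C(Nc1ccc(C(=O)N2CCCCc3sccc32)cc1O)c1ccccc1-c1ccccc1` gives 0.04 mg/kg
- compound 3 `CN(C)C1CCN(C(=O)COc2cc(C(=O)N3CCCCc4sccc43)ccc2NC(=O)c2ccccc2-c2ccccc2)CC1` gives 0.02 mg/kg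

Compound 3 sits level with the other two, as the data show a 1.5-fold lower number from compound 1 to compound 3 (0.18 log units; within the scatter) and a 2.0-fold lower number from compound 2 to compound 3 (0.30 log units; within the scatter) in this series. Compound 4 `CN1CCCN(CCCOc2cc(C(=O)N3CCCCc4sccc43)ccc2NC(=O)c2ccccc2-c2ccccc2)CC1` carries 2-(4-methyl-1,4-diazepan-1-yl)ethyl in place of (4-(dimethylamino)piperidin-1-yl)carbonyl on a saturated chain carbon bound to an oxygen on an aromatic ring. Going by the values given here, those two steps bear on this change, as does a 1.3-fold higher number from compound 1 to compound 2 (0.12 log units; within the scatter) on the same oxygen, yet no measured compound carries the entering group. No step beyond the scatter is expected, and the estimate is a 1.5-fold higher number from compound 3 to compound 4 (0.18 log units; within the scatter) in this assay for this change. For compound 4 the expected value is 0.03 mg/kg, with an estimated range from 0.01 mg/kg to 0.09 mg/kg in this assay.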

Compound 4, dose for 50% inhibition: 0.03 mg/kg
Estimate against measurement, compound 4: no gap at the digits printed; measured number inside the range.
By their numbers in this assay, from the lowest: compounds 3, 1, 4 and 2 (each within the scatter of the next).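

The change swaps the carbonyl-bearing group for 2-(4-methyl-1,4-diazepan-1-yl)ethyl, with its seven-membered ring holding 2 hetero atoms, yet this assay stays level, with a 1.5-fold higher number from compound 3 to compound 4 (0.18 log units; within the scatter) and no change at the digits printed from compound 1 to compound 4 (within the scatter). Even against the hydrogen on the oxygen on an aromatic ring, 3-(4-methyl-1,4-diazepan-1-yl)propyl stays level, with a 1.3-fold lower number from compound 2 to compound 4 (0.12 log units; within the scatter). No measurement here offers an explanation for this flat response.

From the compounds shown here alone, whether a morpholine, a primary amine or a carboxylic acid on this chain, or a longer chain, would also stay level remains open.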